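A few compounds are considered here, and "the series" means these few. Any claim that something is new, unique, unknown or untested is made for them only; others in the source may bear on it.

Measured compounds:
compound 1, `C=C1C[C@]23C[C@@]1(O)CC[C@H]2c1ccc(OS(=O)(=O)c2ccc(C)cc2)c(C)c1[C@@H]3Cn1cc(-c2ccc(Cl)cc2)nn1`, > 20000 nM
compound 2, `C=C1C[C@]23C[C@@]1(O)CC[C@H]2c1ccc(O)c(C)c1[C@@H]3Cn1cc(-c2ccc(OC)cc2)nn1`, > 20000 nM

In a functional assay on SMMC-7721 cells (Homo sapiens) for cytotoxicity, read by MTT assay, with a stated time of 4 days (a lower number here means a stronger inhibitor, a higher number a weaker inhibitor), compound 1 reaches only the limit of the assay, > 20000 nM. In this assay compound 2 likewise gives only a limit, > 20000 nM. Compound 2 therefore has no number of its own to stand on; both values shown sit at the limit of > 20000 nM in this assay, at which 2 of the 2 values shown sit, so nothing in the data separates the two compounds from each other.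

Compound 3 `C=C1C[C@]23C[C@@]1(O)CC[C@H]2c1ccc(O)c(C)c1[C@@H]3Cn1cc(-c2ccc(Cl)cc2)nn1` has not yet been measured. It differs from compound 2 by chloro in place of methoxy on an aromatic carbon. For the measured compounds named here, compound 1 carries the same chloro-bearing ring and still shows only a limit, and no step between compounds with real numbers exists to size this change. The expected step is a number no higher from compound 2 to compound 3 (the limit leaves the size open), meaning no movement beyond the scatter and most likely another limit. Compound 3 is therefore expected to come out around 20000 nM, within a range from 8000 nM to 60000 nM.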

Compound 3, half-maximal inhibitory concentration: > 20000 nM
Compound 3 was reported as a limit; the forecaster's own chance of this, stated with the estimate: 75%; the middle value lies on the limit itself.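

In this assay, compound 3 gives only a limit, as do compound 1 and compound 2, so neither the step from compound 2 nor the step from compound 1 to compound 3 can be read: the limit of > 20000 nM in this assay, at which 3 of the 3 values shown sit.

The compounds shown leave open whether exchanging methoxy for chloro, or hydrogen for (4-methylphenyl)sulfonyl, changes the value at all.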